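Series notes: aryl replacement on the ethyl ester of compound 3

The compounds below may be only part of what the source reports. "The series", "measured", "known", "first", "only" and "open" are said of these compounds alone.

Compound 3 `CCOC(=O)CCCCCOc1cccc(CN(C(=O)c2ccc(-c3cccc4ccccc34)cc2)C(C)C)c1` differs from compound 1 `CC(C)N(Cc1cccc(OCCCCCC(=O)O)c1)C(=O)c1ccc(-c2cccc3ccccc23)cc1` only by the ethyl group. In an ADME assay on BJ cells (Homo sapiens) for cytotoxicity, read by CellTiter-Glo and resazurin assay, with a stated time of 72 h (a higher number here means that more compound is needed for the effect, a lower number that less compound is needed), compound 3 gives only a limit, > 26000 nM. Compound 1 likewise gives a limit, < 1.3 nM. Compound 2 `CC(C)N(Cc1cccc(OCCCCCC(=O)O)c1)C(=O)c1ccc(-c2cccc(F)c2)cc1` gives the limit > 26000 nM. Two measured steps frame compound 3: an at least 20000-fold higher number from compound 1 to compound 3 (4.30 log units; beyond the scatter) and an at least 20000-fold higher number from compound 1 to compound 2 (4.30 log units; beyond the scatter). Compound 4 `CCOC(=O)CCCCCOc1cccc(CN(C(=O)c2ccc(-c3ccoc3)cc2)C(C)C)c1` keeps the ethyl group and changes the aryl: furan-3-yl in place of naphthalen-1-yl on an aromatic carbon. The step that bears on this is the aryl exchange, an at least 20000-fold higher number from compound 1 to compound 2 (4.30 log units; beyond the scatter), where a smaller aryl in place of naphthalen-1-yl left no measurable number. Compound 3 already sits at the limit, so compound 4 is expected to remain there and no step beyond the scatter can appear, a step that the limit leaves unreadable from compound 3 to compound 4. The estimate for compound 4 is 60000 nM, with a range from 26000 nM to 300000 nM.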

Compound 4, half-maximal effective concentration: > 26000 nM
Compound 4 was reported as a limit; the forecaster's own chance of this, stated with the estimate: 95%; the middle value lies beyond the limit too.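

No step can be read from compound 3 to compound 4 in this assay, because both values are limits: the limit of > 26000 nM in this assay, at which 3 of the 4 values shown sit.

The compounds shown leave open how furan-3-yl and naphthalen-1-yl compare on the ethyl ester.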